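Dropping One Methoxy Group: What an Earlier Pair Suggests

The compounds below may be only part of what the source reports. "The series", "measured", "known", "first", "only" and "open" are said of these compounds alone.

Compound 1, `COc1ccc2c(/C=C/C(=O)c3cc(OC)c(OC)c([N+](=O)[O-])c3)c[nH]c2c1`, gives 331 nM in a functional assay on A549 cells (Homo sapiens) for antiproliferative activity, read by MTT assay, with a stated time of 48 h; a higher number here means a weaker inhibitor, a lower number a stronger inhibitor.
Compound 2, `COc1cc(C(=O)/C=C/c2c[nH]c3ccccc23)cc([N+](=O)[O-])c1OC`, gives 1510 nM in this assay.
Compound 3, `COc1ccc2c(/C=C/C(=O)c3cc(OC)c(OC)c(SC)c3)cn(C)c2c1`, gives 156 nM in this assay.

Compound 1 and compound 2 share a core and differ in one place only: hydrogen in place of methoxy on an aromatic carbon. That single change gave a 4.6-fold higher number from compound 1 to compound 2 (0.66 log units; beyond the scatter), so taking the methoxy away weakened the compound clearly, by more than the usual scatter of repeated measurements.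

Compound 3 is built on a different core; the difference between its core and that of compound 1 is not broken down here. What matters is that compound 4, `COc1cc(C(=O)/C=C/c2cn(C)c3ccccc23)cc(SC)c1OC`, which has not yet been measured, stands to compound 3 exactly as compound 2 stands to compound 1: hydrogen in place of methoxy on an aromatic carbon. The place of the change is described in the same words in both pairs, so this is the same change made on a second core.

Going by the values given here, with only one earlier example of this change, the expectation for compound 4 rests on compound 1 and compound 2 alone, and on their step of a 4.6-fold higher number from compound 1 to compound 2 (0.66 log units; beyond the scatter). The step from compound 3 is therefore expected to be of a similar size, a 4.2-fold higher number from compound 3 to compound 4 (0.62 log units; beyond the scatter), with a wide margin because a single pair gives no sense of how steady the effect is across cores. Compound 4 is expected to give about 650 nM in this assay, most likely between 250 nM and 1800 nM.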

Compound 4, half-maximal inhibitory concentration: 188 nM
For compound 4 the middle estimate is 3.5-fold (0.54 log units) above the measured one; measured number outside the range, below it.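

On the second core, putting hydrogen in place of methoxy gave a 1.2-fold higher number from compound 3 to compound 4 (0.08 log units; within the scatter) in this assay, so on this core the change has no effect that can be told apart from ordinary repeat-to-repeat variation. The clear loss seen on the first core therefore did not carry over to the second, and the two steps differ by more than chance scatter would readily explain: the same change on two cores in this assay, a 4.6-fold higher number (0.66 log units; beyond the scatter) from compound 1 to compound 2 and a 1.2-fold higher number (0.08 log units; within the scatter) from compound 3 to compound 4, 3.8-fold (0.58 log units) apart, beyond the scatter of two such steps This shows that the size of this step depends on the core it is made on, at least across these two pairs, but it does not show which feature of the cores is responsible, and two pairs cannot say which result is the more typical for the series.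

The compounds shown leave open how the same change would behave on a third core, which would help show whether either pair is the exception. They also leave open what other groups would do on that aromatic carbon, such as an ethoxy group, an amine or a single fluorine atom, and whether any of these would separate the two cores in the same way.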